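The compounds below may be only part of what the source reports. "The series", "measured", "known", "first", "only" and "open" are said of these compounds alone.

Measured so far in an in vitro ADME assay on microsomes from liver (Homo sapiens) for metabolic stability; on this read-out lower numbers stand for slow clearance and higher numbers for fast clearance:

Compound 1 `Fc1ccccc1Cc1nc(-c2nc(C(F)F)n[nH]2)n2ccccc12` gives 62 mL.min-1.g-1
Compound 2 `Cc1ncc(Cc2nc(-c3nc(C(F)(F)F)n[nH]3)n3ccccc23)cn1` gives < 8 mL.min-1.g-1 as a limit of the assay
Compound 3 `Fc1ccccc1Cc1nc(-c2nc(C(F)(F)F)n[nH]2)n2cccnc12` gives 17 mL.min-1.g-1

Compound 1 stands highest of the two actual numbers, with 62 mL.min-1.g-1 as its clearance. Compound 3 comes nearest with 17 mL.min-1.g-1 as its value, and this gap lies beyond the scatter.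

Compound 4 `Fc1ccccc1Cc1nc(-c2nc(C(F)(F)C(F)(F)F)n[nH]2)n2ccccc12` keeps the core of compound 1 and changes one group, with trifluoromethyl in place of hydrogen on a saturated chain carbon bound to an aromatic carbon and two fluorine atoms. The count of this difference is trifluoromethyl in place of hydrogen on a saturated chain carbon bound to an aromatic carbon and two fluorine atoms (cut one bond further out, it reads difluoromethyl to 1,1,2,2,2-pentafluoroethyl).

For the measured compounds named here, no measured pair shows this change on its own, so the forecast is loose. The expected step of a 1.4-fold lower number from compound 1 to compound 4 (0.14 log units; within the scatter) is slightly downward and stays within the scatter. The starting point is compound 1 at 62 mL.min-1.g-1 in this assay and the range is kept wide. For compound 4 the estimated clearance is 45 mL.min-1.g-1 with an expected range from 18 mL.min-1.g-1 to 110 mL.min-1.g-1 in this assay when it is measured.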

Compound 4, intrinsic clearance in microsomes: 92 mL.min-1.g-1
Compound 4: the middle estimate sits 2.0-fold (0.31 log units) below what was measured, and the stated range covers the measured number.
By their numbers in this assay, from the lowest: compound 3; then compounds 1 and 4 (each within the scatter of the next). At a limit, below all of these: compound 2.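

In this assay, replacing difluoromethyl with 1,1,2,2,2-pentafluoroethyl on the core of compound 1 gives a 1.5-fold higher number from compound 1 to compound 4 (0.17 log units; within the scatter). For the compounds shown here, this is the first direct reading of a change at this place with the rest of the molecule held constant, and it shows that putting trifluoromethyl in place of hydrogen on this carbon leaves the two compounds indistinguishable on this read-out. Nothing shown here explains why the numbers stay so close.

Going by these compounds, whether a different kind of group at this place, such as an amine or a carboxylic acid, would move the clearance beyond the scatter remains open. On these data alone, it is also open whether the same change would read alike on a core other than that of compound 1.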